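Swapping phenyl for cyclohexyl on two related amide cores

The compounds below may be only part of what the source reports. "The series", "measured", "known", "first", "only" and "open" are said of these compounds alone.

The three measured compounds and their numbers:
compound 1, `O=C(COc1ccc(-c2ccccc2)cc1)Nc1ccccc1-c1nc2ncccc2[nH]1`: 1100 nM
compound 2, `O=C(COc1ccc(C2CCCCC2)cc1)Nc1ccccc1-c1nc2ncccc2[nH]1`: 650 nM
compound 3, `O=C(COc1ccc(-c2ccccc2)cc1)Nc1ccc(-c2nc3ncccc3[nH]2)cc1`: 620 nM

All three were tested in an assay on brain for inhibition of Fatty-acid amide hydrolase 1 (Rattus norvegicus); a lower number here means a stronger inhibitor, a higher number a weaker inhibitor. Compound 1 gives 1100 nM in this assay. Going by the values given here, the one change that sets compound 2 apart is cyclohexyl in place of phenyl on an aromatic carbon; in this assay compound 2 gives 650 nM, so that a 1.7-fold lower number from compound 1 to compound 2 (0.23 log units; within the scatter).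

Compound 3 has the same atoms as compound 1 joined differently; the difference between the two cores is not broken down here. In this assay compound 3 gives 620 nM, a number that sits within the usual scatter of both compound 1 and compound 2, so no order among the three can be read from these numbers.

Compound 4, `O=C(COc1ccc(C2CCCCC2)cc1)Nc1ccc(-c2nc3ncccc3[nH]2)cc1`, has not yet been measured. It stands to compound 3 as compound 2 stands to compound 1: the change is cyclohexyl in place of phenyl on an aromatic carbon, and the two place descriptions are the same word for word, so this is the same change made on the second core.

The expectation for compound 4 rests on a single earlier example. Because the same change gave a 1.7-fold lower number from compound 1 to compound 2 (0.23 log units; within the scatter), compound 4 is estimated to show a step of a 1.6-fold lower number from compound 3 to compound 4 (0.19 log units; within the scatter) in this assay. With that, compound 4 is expected to come out near 400 nM, and a result anywhere from 150 nM to 1000 nM would not be surprising, since a single step within the scatter gives only a weak guide.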

Compound 4, half-maximal inhibitory concentration: 1500 nM
The estimate for compound 4 lay 3.8-fold (0.57 log units) below the measured number, outside the stated range (above it).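

In this assay, putting cyclohexyl in place of phenyl on the second core gave a 2.4-fold higher number from compound 3 to compound 4 (0.38 log units; beyond the scatter), a step beyond the usual scatter. Set beside the earlier example, the same change does not behave alike on the two cores: the same change on two cores in this assay, a 1.7-fold lower number (0.23 log units; within the scatter) from compound 1 to compound 2 and a 2.4-fold higher number (0.38 log units; beyond the scatter) from compound 3 to compound 4, 4.1-fold (0.61 log units) apart, beyond the scatter of two such steps

This shows that, in this series, the step seen on one core cannot simply be carried over to the other as a fixed amount, even though the group swapped and its place are the same. Going by these compounds alone, it does not show why the two cores differ, and with only one pair on each core, it says nothing about how the change would behave on any further core.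

The compounds shown leave open whether the two cores part ways only for this swap of phenyl and cyclohexyl, or for other groups as well. Pairs on both cores carrying cyclopentyl, a hexyl chain or an amine at the same place, on an aromatic carbon para to a large group, would help to settle that question.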